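Longer Amide Chains and Cytotoxicity in Vero Cells

The source may report more compounds than this note shows. Statements on the series, on what has been measured and on what is new or still open speak of the compounds shown alone.

Compound 1, `CCCCCC(=O)NCC(C)(C)CC1=C(O)C(=O)c2ccccc2C1=O`, gives 46600 nM in an ADME assay on Vero cells (Chlorocebus sabaeus) for cytotoxicity, read by reporter gene assay, with a stated time of 4 days; a higher number here means a weaker inhibitor, a lower number a stronger inhibitor.
Compound 2, `CCCCCCC(=O)NCC(C)(C)CC1=C(O)C(=O)c2ccccc2C1=O`, gives 24800 nM.
Compound 3, `CCCCCCCCCC(=O)NCC(C)(C)CC1=C(O)C(=O)c2ccccc2C1=O`, gives 15000 nM.

All three share one core and differ only in the length of the saturated chain on the amide. Going from compound 1 to compound 2 the change is methyl in place of hydrogen on a saturated chain carbon, five bonds along the chain from a carbonyl carbon, and it made a step of a 1.9-fold lower number from compound 1 to compound 2 (0.27 log units; within the scatter). The larger change from compound 1 to compound 3 is butyl in place of hydrogen on a saturated chain carbon, five bonds along the chain from a carbonyl carbon, with a step of a 3.1-fold lower number from compound 1 to compound 3 (0.49 log units; beyond the scatter); from compound 2 to compound 3 the step was a 1.7-fold lower number from compound 2 to compound 3 (0.22 log units; within the scatter).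

Compound 4, `CCCCCCCCCCC(=O)NCC(C)(C)CC1=C(O)C(=O)c2ccccc2C1=O`, has not yet been measured. It differs from compound 3 by methyl in place of hydrogen on a saturated chain carbon, nine bonds along the chain from a carbonyl carbon. Among the compounds with values here, this is the same kind of change as the one from compound 1 to compound 2, but the place is not the same: there it sat five bonds along the chain from a carbonyl carbon, here nine bonds along.

For compound 4 the expected step is a 1.4-fold lower number from compound 3 to compound 4 (0.13 log units; within the scatter), because each earlier lengthening gave a 1.9-fold lower number from compound 1 to compound 2 (0.27 log units; within the scatter) and a 1.7-fold lower number from compound 2 to compound 3 (0.22 log units; within the scatter). The estimated value for compound 4 is 11000 nM, likely between 5000 nM and 25000 nM.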

Compound 4, half-maximal inhibitory concentration: 14900 nM
Compound 4: the middle estimate sits 1.4-fold (0.13 log units) below what was measured; low and high end bracket the measured number.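

In this assay, the new compound gives a 1.0-fold lower number from compound 3 to compound 4 (0.00 log units; within the scatter) and a 1.7-fold lower number from compound 2 to compound 4 (0.22 log units; within the scatter), and only the widest comparison lies beyond the scatter, with a 3.1-fold lower number from compound 1 to compound 4 (0.50 log units; beyond the scatter). Set beside the earlier result, the methyl change reads alike in both settings once the scatter is allowed for: the same change on two cores in this assay, a 1.9-fold lower number (0.27 log units; within the scatter) from compound 1 to compound 2 and a 1.0-fold lower number (0.00 log units; within the scatter) from compound 3 to compound 4, 1.9-fold (0.27 log units) apart, within the scatter of two such steps The butyl change agrees in the same way: the same change on two cores in this assay, a 3.1-fold lower number (0.49 log units; beyond the scatter) from compound 1 to compound 3 and a 1.7-fold lower number (0.22 log units; within the scatter) from compound 2 to compound 4, 1.9-fold (0.27 log units) apart, within the scatter of two such steps These pairs give no sign that either change behaves differently from one core to another, but they do not prove that its size carries over unchanged, since the gaps between such small steps are too uncertain to settle that and the methyl sits five bonds along the chain in one case and nine bonds along in the other.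

The compounds shown leave open whether a longer chain would give a clearly different number in this assay. They also leave open what a chain ending in an amine or a carboxylic acid would give there.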